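Dropping One Trifluoromethyl From the Strongest Urea

A few compounds are considered here, and "the series" means these few. Any claim that something is new, unique, unknown or untested is made for them only; others in the source may bear on it.

Three analogues built on a shared core have been tested in a functional assay on UO-31 cells (Homo sapiens) for inhibition, read by sulforhodamine B assay, with a stated time of 48 h; on this read-out higher numbers stand for weaker inhibition and lower numbers for stronger inhibition. Compound 1 `O=C(Nc1cccc(-n2cc(-c3ccncc3)c(-c3cc(O)cc(Cl)c3)n2)c1)Nc1ccc(Cl)c(Cl)c1` gives 1910 nM. Compound 2 `COc1cc(Cl)cc(-c2nn(-c3cccc(NC(=O)Nc4ccc(Cl)c(C(F)(F)F)c4)c3)cc2-c2ccncc2)c1` gives 1660 nM. Compound 3 `COc1cc(Cl)cc(-c2nn(-c3cccc(NC(=O)Nc4cc(C(F)(F)F)cc(C(F)(F)F)c4)c3)cc2-c2ccncc2)c1` gives 260 nM, the lowest of the three numbers; compound 2 stands nearest with a higher number and compound 1 furthest, both gaps beyond the scatter, so compound 3 is the strongest inhibitor of this set.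

Compound 4 `COc1cc(Cl)cc(-c2nn(-c3cccc(NC(=O)Nc4cccc(C(F)(F)F)c4)c3)cc2-c2ccncc2)c1` differs from compound 3 in one place: hydrogen in place of trifluoromethyl on an aromatic carbon. Among the measured compounds shown here, no pair of measured compounds shows this same change, so the size of the step cannot be read from a precedent. For the measured compounds named here, the only guide is that compound 3, whose urea ring carries two trifluoromethyl groups, gives 260 nM, while compound 2, whose urea ring carries one trifluoromethyl group and a chlorine, gives 1660 nM. On this basis a move toward weaker inhibition is expected for the change from compound 3 to compound 4, of size a 3.1-fold higher number from compound 3 to compound 4 (0.49 log units; beyond the scatter), though the scatter leaves room for a smaller move. Compound 4 is estimated at 800 nM, expected to fall between 250 nM and 2500 nM.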

Compound 4, half-maximal inhibitory concentration: 1030 nM
For compound 4 the middle estimate is 1.3-fold (0.11 log units) below the measured one; measured number inside the range.
By their numbers in this assay, from the lowest: compound 3; then compounds 4, 2 and 1 (each within the scatter of the next).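

In this assay the loss of one trifluoromethyl can now be read directly: hydrogen in place of trifluoromethyl on an aromatic carbon, meta to a trifluoromethyl group, gives a 4.0-fold higher number from compound 3 to compound 4 (0.60 log units; beyond the scatter) and shows that this one position accounts for a change beyond the scatter. On the urea ring that keeps a single trifluoromethyl group, hydrogen in place of chloro on an aromatic carbon gives a 1.6-fold lower number from compound 2 to compound 4 (0.21 log units; within the scatter) and so leaves no readable difference between the two compounds, which means this chloro does not bring back the lower number seen with the second trifluoromethyl group in compound 3. No measurement at hand offers an explanation for either step.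

The compounds shown leave open whether a group other than trifluoromethyl at this position, such as a nitrile, an amine or a carboxylic acid, could match compound 3 at 260 nM or would behave like hydrogen. They also leave open whether the same exchange of trifluoromethyl for hydrogen would give a step of similar size on the ring position where the other trifluoromethyl group remains.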